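Cyano on the benzyl group: working notes on compound 3

The source may hold more compounds than are shown below. What is called first, only, known or untested is meant among the compounds shown, and "the series" means these compounds.

Measured so far:
compound 1 `COc1ccccc1N1CCN(CCCNC(=O)NN(Cc2ccccc2)c2ccc(Cl)cc2)CC1` — 2.9 nM
compound 2 `COc1ccc(N(Cc2ccccc2)NC(=O)NCCCN2CCN(c3ccccc3OC)CC2)cc1` — 1.7 nM

Among the measured compounds shown here, in an assay on CHO cells for displacement of a labelled ligand from D(4) dopamine receptor (Homo sapiens), read by radioligand binding (on this read-out lower numbers stand for stronger inhibition and higher numbers for weaker inhibition), compound 2 and compound 1 sit within the scatter of each other; the only measured step, a 1.7-fold lower number from compound 1 to compound 2 (0.23 log units; within the scatter), concerns methoxy replacing chloro and says nothing about the benzyl group. Compound 3 `COc1ccc(N(Cc2ccc(C#N)cc2)NC(=O)NCCCN2CCN(c3ccccc3OC)CC2)cc1` carries cyano in place of hydrogen on an aromatic carbon on the benzyl group of compound 2. For the measured compounds named here, no measured step bears on this change, so no shift beyond the scatter is expected: a 1.5-fold higher number from compound 2 to compound 3 (0.17 log units; within the scatter). Compound 3 is estimated at 2.5 nM in this assay, with a range from 0.8 nM to 8 nM reflecting the lack of a comparable step.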

Compound 3, inhibition constant: 16 nM
Compound 3: middle estimate off by 6.4-fold (0.81 log units), on the low side; measured number above the stated range.
By their numbers in this assay, from the lowest: compounds 2 and 1 (each within the scatter of the next); then compound 3.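

In this assay, among the compounds shown here, the benzyl group proves sensitive to substitution: 4-cyanobenzyl in place of benzyl gives a 9.4-fold higher number from compound 2 to compound 3 (0.97 log units; beyond the scatter) and is the first step beyond the scatter. The earlier step, methoxy in place of chloro, stayed within the scatter and did not touch this group. No available evidence explains this shift.

Going by these compounds, whether a fluoro, a methoxy, an amine or a carboxylic acid at this place gives a comparable step remains open. Also open, on these data alone, is whether cyano gives the same step on compound 1, which carries chloro instead of methoxy.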